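This account rests on a few compounds, and the source may have more. Where it says the series, first, only, none or still open, it means among the compounds named here.

Compound 1, with the structure `COc1cc(C=C(C(=O)/C=C/c2cccc(OC)c2OC)C(=O)/C=C/c2cccc(OC)c2OC)cc(Br)c1O`, is tested in a functional assay on MCF7 cells (Homo sapiens) for antiproliferative activity, read by sulforhodamine B assay, with a stated time of 48 h; on this read-out higher numbers stand for weaker inhibition and lower numbers for stronger inhibition; in this read-out compound 1 gives 360 nM. Compound 2, with the structure `COc1cc(C=C(C(=O)/C=C/c2cccc(OC)c2OC)C(=O)/C=C/c2cccc(OC)c2OC)cc(OC)c1O`, differs from compound 1 by methoxy in place of bromo on an aromatic carbon. In this assay compound 2 gives 460 nM, so the step of a 1.3-fold higher number from compound 1 to compound 2 (0.11 log units; within the scatter) stays inside the ordinary spread of repeat measurements, and the two numbers cannot be ranked against each other.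

Compound 3, with the structure `COc1cc(OC)c(/C=C/C(=O)C(=Cc2cc(Br)c(O)c(OC)c2)C(=O)/C=C/c2c(OC)cc(OC)cc2OC)c(OC)c1`, is built on a different core; how that core differs from the core of compound 1 is not broken down here. In this assay compound 3 gives 1460 nM, the highest number of the three measured compounds, beyond the scatter from both compound 1 and compound 2.

Compound 4, with the structure `COc1cc(OC)c(/C=C/C(=O)C(=Cc2cc(OC)c(O)c(OC)c2)C(=O)/C=C/c2c(OC)cc(OC)cc2OC)c(OC)c1`, is not yet measured. It differs from compound 3 by methoxy in place of bromo on an aromatic carbon, the same change that carried compound 1 to compound 2, at a place described in the same words. Because the step of a 1.3-fold higher number from compound 1 to compound 2 (0.11 log units; within the scatter) stayed within the scatter, the step from compound 3 to compound 4 is expected to be similar, about a 1.3-fold higher number from compound 3 to compound 4 (0.11 log units; within the scatter). Compound 4 is therefore estimated at 1900 nM in this assay, within a range from 900 nM to 4000 nM.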

Compound 4, half-maximal inhibitory concentration: 1030 nM
The estimate for compound 4 lay 1.8-fold (0.27 log units) above the measured number; the measured number falls inside the stated range.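

Replacing bromo with methoxy, which turns the 3-bromo-4-hydroxy-5-methoxyphenyl group into 4-hydroxy-3,5-dimethoxyphenyl, gives a 1.4-fold lower number from compound 3 to compound 4 (0.15 log units; within the scatter) in this assay, so these two numbers cannot be ranked against each other either. Set side by side, the two steps cannot be told apart: the same change on two cores in this assay, a 1.3-fold higher number (0.11 log units; within the scatter) from compound 1 to compound 2 and a 1.4-fold lower number (0.15 log units; within the scatter) from compound 3 to compound 4, 1.8-fold (0.26 log units) apart, within the scatter of two such steps. On both cores shown, this change therefore leaves the number within the ordinary spread of repeat measurements, and the opposite directions of the two steps carry no meaning; this does not show that the change would behave the same way on a third core, and two pairs of compounds are too few to support a general rule.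

The compounds shown leave open whether an amine, a carboxylic acid or a longer chain such as propoxy at this place would move the number beyond the scatter on either core. They also leave open how much the hydroxy group on the same ring contributes, as it is present in all four compounds.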